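Swapping Trifluoromethyl for Methoxyphenyl on the Shared Core

The compounds below may be only part of what the source reports. "The series", "measured", "known", "first", "only" and "open" are said of these compounds alone.

Compound 1, `CCOC(=O)c1cnc(C(F)(F)F)nc1NN1C(=O)C=C(C)C1=O`, gives 1000 nM in a functional assay on Jurkat cells for inhibition of nuclear factor NF-kappa-B complex (Homo sapiens); on this read-out lower numbers stand for stronger inhibition and higher numbers for weaker inhibition.
Compound 2, `CCOC(=O)c1cnc(-c2cccs2)nc1NN1C(=O)C=C(C)C1=O`, gives 20 nM in this assay.
Compound 3, `CCOC(=O)c1cnc(-c2cc(Cl)nc(Cl)c2)nc1NN1C(=O)C=C(C)C1=O`, gives 2000 nM in this assay.

Among these three numbers compound 1 stands second highest; compound 3 is nearest, a 2.0-fold higher number from compound 1 to compound 3 (0.30 log units; within the scatter), and compound 2 is furthest, a 50-fold lower number from compound 1 to compound 2 (1.70 log units; beyond the scatter). Compound 4, `CCOC(=O)c1cnc(-c2ccc(OC)cc2)nc1NN1C(=O)C=C(C)C1=O`, has not yet been measured. Compared with compound 1, the change is 4-methoxyphenyl in place of trifluoromethyl on an aromatic carbon. Within the data shown here, two measured steps bear on this, since both also put an aromatic ring in place of trifluoromethyl on that aromatic carbon: a 50-fold lower number from compound 1 to compound 2 (1.70 log units; beyond the scatter) was large, whereas a 2.0-fold higher number from compound 1 to compound 3 (0.30 log units; within the scatter) stayed within the scatter. The two ring replacements therefore point in different directions, and nothing measured here says which one a methoxyphenyl ring will follow. A lower number is nevertheless expected for compound 4 in this assay, and a step of a 10-fold lower number from compound 1 to compound 4 (1.00 log units; beyond the scatter) is the expectation. The estimate for compound 4 is 100 nM, within a range from 15 nM to 1000 nM.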

Compound 4, half-maximal inhibitory concentration: 900 nM
For compound 4 the middle estimate is 9.0-fold (0.95 log units) below the measured one, and the stated range covers the measured number.
By their numbers in this assay, from the lowest: compound 2; then compounds 4, 1 and 3 (each within the scatter of the next, the first and the last beyond it).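

In this assay, putting an aromatic ring on this carbon does not by itself lower the number: 4-methoxyphenyl in place of trifluoromethyl gives a 1.1-fold lower number from compound 1 to compound 4 (0.05 log units; within the scatter), which is no real change. Thiophen-2-yl now stands apart from both other rings, with a 45-fold higher number from compound 2 to compound 4 (1.65 log units; beyond the scatter), while the two rings bearing substituents lie much closer together, with a 2.2-fold lower number from compound 3 to compound 4 (0.35 log units; beyond the scatter). Nothing available here explains why these rings behave so differently.

The compounds shown leave open whether the low number of compound 2 is specific to thiophen-2-yl or would also appear with thiophen-3-yl or furan-2-yl. They also leave open what an unsubstituted phenyl ring would give, and so whether the methoxy group on the ring of compound 4 matters at all.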